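The compounds below may be only part of what the source reports. "The series", "measured", "known", "first", "only" and "open" are said of these compounds alone.

Measured so far in a functional assay on SW-620 cells (Homo sapiens) for inhibition (a lower number here means a stronger inhibitor, a higher number a weaker inhibitor), are two compounds:
- compound 1 (`COc1ccc(-c2cc(-c3cc(OC)c(OC)c(OC)c3)[nH]n2)cc1`) gives (5150 nM; 3410 nM (2 entries))
- compound 2 (`COc1cc(-c2cc(-c3cc(OC)c(OC)c(OC)c3)[nH]n2)cc(OC)c1OC`) gives (10000 nM)

Compound 2 rests on one number in this assay and a further entry for it gave no single value, so its position is only loosely fixed. Compound 1 has repeat entries (the several entries of compound 1 in this assay, 5150 nM; 3410 nM (2 entries)), and these show how far two readings of the same compound can lie apart.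

Compound 3 (`COc1ccc(-c2cc(-c3cc(OC)c(OC)c(OC)c3)[nH]n2)cc1OC`) differs from compound 2 by one change (hydrogen in place of methoxy on an aromatic carbon): hydrogen in place of methoxy on an aromatic carbon. Within the data shown here, no measured step between close neighbours is available to size this change. Among the measured compounds shown here, the only guide is that compound 1 (5150 nM; 3410 nM (2 entries)) and compound 2 (10000 nM) lie in one broad range.

The estimated change (a 1.7-fold lower number from compound 2 to compound 3 (0.22 log units; within the scatter)) in this assay is small, towards somewhat stronger inhibition, and it may not clear the usual scatter. For compound 3 the estimated value is 6000 nM (expected range 2500 nM to 15000 nM).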

Compound 3, half-maximal inhibitory concentration: 230 nM
Beside the measured number, compound 3's estimate is 26-fold (1.42 log units) above it, outside the stated range (below it).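

Among these compounds, removing one methoxy from an aromatic carbon, ortho to a methoxy group and meta to a large group, gives a 43-fold lower number from compound 2 to compound 3 (1.64 log units; beyond the scatter) in this assay, so this single position matters far more than the earlier compounds could show. The step is also much wider than the gap between two readings of the same compound: the several entries of compound 1 in this assay, 5150 nM; 3410 nM (2 entries). Fewer methoxy groups do not simply mean a lower number, however: compound 3 gives 230 nM, and compound 1, with one methoxy fewer on that ring, gives 5150 nM; 3410 nM (2 entries), a higher number.

The compounds shown do not tell whether it is the loss of the methoxy at this place alone that counts or the particular pattern of methoxy groups left on the ring, and they give no reason for the size of the step. Going by these compounds, it also remains open how a fluorine, a hydroxyl or an amine would behave at this position, and whether the low number of compound 3 would survive a change to the methoxy groups on its other ring.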